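Para substituent swap on the benzyl ring: chloro to methyl

The source may report more compounds than this note shows. Statements on the series, on what has been measured and on what is new or still open speak of the compounds shown alone.

In an assay on CHO cells for antagonist activity at transient receptor potential cation channel subfamily V member 1 (Homo sapiens), read by scintillation counting, with a stated time of 5 min (on this read-out lower numbers stand for stronger inhibition and higher numbers for weaker inhibition), compound 2 `CC(C(=O)NCc1ccc(C(F)(F)F)nc1N(Cc1ccc(Cl)cc1)S(=O)(=O)c1ccc(F)cc1)c1ccc(NS(C)(=O)=O)c(F)c1` gives 6 nM; compound 1 `CC(C(=O)NCc1ccc(C(F)(F)F)nc1N(Cc1ccccc1)S(=O)(=O)c1ccc(F)cc1)c1ccc(NS(C)(=O)=O)c(F)c1` gives 3.87 nM, and the two numbers lie within the scatter of each other. For the measured compounds named here, the only step measured so far, a 1.6-fold higher number from compound 1 to compound 2 (0.19 log units; within the scatter), is chloro in place of hydrogen on an aromatic carbon, a step that stayed within the scatter. Compound 3 `Cc1ccc(CN(c2nc(C(F)(F)F)ccc2CNC(=O)C(C)c2ccc(NS(C)(=O)=O)c(F)c2)S(=O)(=O)c2ccc(F)cc2)cc1` carries methyl in place of chloro on an aromatic carbon. Going by the values given here, since the one measured change at this place gave a 1.6-fold higher number from compound 1 to compound 2 (0.19 log units; within the scatter), no step beyond the scatter is expected, no change at the digits printed from compound 2 to compound 3 (within the scatter). Compound 3 is therefore estimated at 6 nM, with a range from 2.5 nM to 14 nM.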

Compound 3, inhibition constant: 7.08 nM
Beside the measured number, compound 3's estimate is 1.2-fold (0.07 log units) below it; the range from low to high includes it.
By their numbers in this assay, from the lowest: compounds 1, 2 and 3 (each within the scatter of the next).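

In this assay this position on the benzyl ring now carries hydrogen, chloro or methyl, and the swap of chloro for methyl gives a 1.2-fold higher number from compound 2 to compound 3 (0.07 log units; within the scatter). Adding methyl in place of hydrogen gives a 1.8-fold higher number from compound 1 to compound 3 (0.26 log units; within the scatter), so the three compounds cannot be told apart at this position. Nothing on hand explains this result.

Still open, on these data alone, is whether an amine or a carboxylic acid at this position would give a number beyond the scatter from these three. The compounds shown also leave open whether a longer chain would do so.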